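Lengthening a Sulfonyl Chain by One Carbon

A few compounds are considered here, and "the series" means these few. Any claim that something is new, unique, unknown or untested is made for them only; others in the source may bear on it.

Compound 1 `CCCCCS(=O)(=O)/C=C/c1ccc(O)c(O)c1` gives, in a functional assay, read by fluorescence and spectrophotometry, with a stated time of 1 h (on this read-out higher numbers stand for an effect only at larger amounts of compound and lower numbers for an effect already at smaller amounts), a value of 8100 nM. Compound 2 `CCCCCCCCCS(=O)(=O)/C=C/c1ccc(O)c(O)c1` gives, in this assay, a value of 7700 nM, a number that sits within the scatter of that of compound 1. Going by the values given here, the only measured step, a 1.1-fold lower number from compound 1 to compound 2 (0.02 log units; within the scatter), is thus no real change. Compound 3 `CCCCCCCCCCS(=O)(=O)/C=C/c1ccc(O)c(O)c1` differs from compound 2 by methyl in place of hydrogen on a saturated chain carbon, nine bonds along the chain from a sulfonyl sulfur. Because the larger change a 1.1-fold lower number from compound 1 to compound 2 (0.02 log units; within the scatter) stayed within the scatter, this smaller one is expected to give no change at the digits printed from compound 2 to compound 3 (within the scatter). Compound 3 is therefore estimated at 7700 nM, with a range from 3900 nM to 15000 nM.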

Compound 3, half-maximal effective concentration: 6800 nM
Compound 3: the middle estimate sits 1.1-fold (0.05 log units) above what was measured, and the stated range covers the measured number.
By their numbers in this assay, from the lowest: compounds 3, 2 and 1 (each within the scatter of the next).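

Methyl in place of hydrogen on a saturated chain carbon, nine bonds along the chain from a sulfonyl sulfur, gives a 1.1-fold lower number from compound 2 to compound 3 (0.05 log units; within the scatter), so this change makes no real difference in this assay. Even the larger change gives a 1.2-fold lower number from compound 1 to compound 3 (0.08 log units; within the scatter), and the three chains cannot be told apart. No measurement at hand explains this flat result. Still open, going by these compounds, is whether a methyl on the sulfonyl sulfur, or a chain carrying a carboxylic acid or an amine, would move the number beyond the scatter.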